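Trading a nitrile for an amide-bearing amine on the shared core

This account rests on a few compounds, and the source may have more. Where it says the series, first, only, none or still open, it means among the compounds named here.

Measured compounds:
compound 1 `CCNC(=O)Nc1cc(=O)oc2cc(OCc3cccc(Cl)c3)ccc12` — 31600 nM
compound 2 `O=C(O)CCc1cc(=O)oc2cc(OCc3cccc(Cl)c3)ccc12` — 1200 nM
compound 3 `N#CCCc1cc(=O)oc2cc(OCc3cccc(Cl)c3)ccc12` — 28.8 nM

All three were tested in an assay on brain (strain Sprague-Dawley) for inhibition of Amine oxidase [flavin-containing] B (Rattus norvegicus), read by spectrophotometry; on this read-out higher numbers stand for weaker inhibition and lower numbers for stronger inhibition. Among them compound 3 gives the lowest number, that is the strongest inhibition: compound 2 is the nearest with a 42-fold lower number from compound 2 to compound 3 (1.62 log units; beyond the scatter) read in reverse, and compound 1 is the furthest, a 1100-fold lower number from compound 1 to compound 3 (3.04 log units; beyond the scatter) read in reverse.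

Compound 4 `NC(=O)CNc1cc(=O)oc2cc(OCc3cccc(Cl)c3)ccc12` has not yet been measured. It differs from compound 3 in one place: (carbamoylmethyl)amino in place of 2-cyanoethyl on an aromatic carbon.

Going by the values given here, two measured steps bear on this change. Compound 1, which also carries a nitrogen-linked group with hydrogen-bond donors on that same aromatic carbon, stands far above compound 3: a 1100-fold lower number from compound 1 to compound 3 (3.04 log units; beyond the scatter). Compound 2, whose chain ends in a carboxy group instead of a nitrile, also sits well above: a 42-fold lower number from compound 2 to compound 3 (1.62 log units; beyond the scatter). Both steps moved the number sharply when the nitrile was absent, so the reverse move, to the (carbamoylmethyl)amino group, is expected to raise the number by a large amount, well beyond the scatter: a 280-fold higher number from compound 3 to compound 4 (2.44 log units; beyond the scatter). For compound 4 in this assay the estimated value is 8000 nM, with a range from 1500 nM to 40000 nM.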

Compound 4, half-maximal inhibitory concentration: 49 nM
For compound 4 the middle estimate is 160-fold (2.21 log units) above the measured one; measured number below the stated range.
By their numbers in this assay, from the lowest: compounds 3 and 4 (each within the scatter of the next); then compound 2; then compound 1.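

The nitrile of compound 3 turns out not to be required for strong inhibition at this position: in this assay the (carbamoylmethyl)amino group of compound 4 cannot be told apart from the 2-cyanoethyl group (a 1.7-fold higher number from compound 3 to compound 4 (0.23 log units; within the scatter)). A nitrogen attached to this aromatic carbon is also no obstacle in itself, since the two compounds that share that nitrogen stand far apart when carbamoylmethyl replaces ethylcarbamoyl on it (a 640-fold lower number from compound 1 to compound 4 (2.81 log units; beyond the scatter)). The large gap therefore follows the group carried on the nitrogen, and a chain ending in a carboxy group is likewise not matched by the new group (a 24-fold lower number from compound 2 to compound 4 (1.39 log units; beyond the scatter)), so a nitrile is only one of the chain ends compatible with strong inhibition here.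

Nothing measured here explains why these groups give such different numbers. The compounds shown also leave open how much of the result belongs to the end amide of compound 4 and how much to its nitrogen link, a question that a plain amine, or a longer chain ending in the same amide, on this aromatic carbon would help to settle.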